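The source may report more compounds than this note shows. Statements on the series, on what has been measured and on what is new or still open speak of the compounds shown alone.

Compound 1, `O=C(O)CCCCCCN1C(=O)CCC1CCC(O)CCc1ccccc1`, is the starting point of this comparison. In an assay on HEK293 cells for binding affinity to prostaglandin E2 receptor EP2 subtype (Rattus norvegicus) (a lower number here means a stronger inhibitor, a higher number a weaker inhibitor), compound 1 gives > 3200 nM, which is a limit of the assay and not a measured number. Its companion compound 2, `O=C(O)CCCCCCN1C(=O)CC[C@@H]1CC[C@@H](O)CCc1ccccc1`, has the same atoms and bonds but is drawn with a defined configuration at the two places where compound 1 is drawn without one. In this assay compound 2 gives > 3200 nM, which is again a limit of the assay. The step that the two limits leave unreadable from compound 1 to compound 2 cannot be read as a size, because the limit of > 3200 nM in this assay, at which 2 of the 2 values shown sit, leaves both ends of it open and the fact that one of compounds 1 and 2 is drawn with a defined configuration and the other without, at the place where they differ only tells where the two drawings differ. Compound 3, `O=C(O)CCCCCCN1C(=O)CCC1CCC(O)Cc1cccc(Cl)c1`, carries 3-chlorophenyl in place of benzyl on a saturated chain carbon, two bonds along the chain from an oxygen on a saturated carbon. Among the compounds with values here, no measured step touches this change, and the single measured step available has no readable size, so there is nothing to transfer to it. Compound 3 is therefore expected to land near 5000 nM, within a range from 2000 nM to 20000 nM. The most likely outcome is that this assay again reports only a limit for compound 3. The estimated step that the limit leaves unreadable from compound 1 to compound 3 is accordingly expected to be flat, without a direction that rises above the scatter.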

Compound 3, half-maximal inhibitory concentration: > 3200 nM
Compound 3 gave a limit, no number (the forecaster's own chance of this, stated with the estimate: 80%); the middle value does not contradict the limit.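

Compound 3 gives > 3200 nM in this assay, which is a limit of the assay and not a number. Compound 1 also gives only a limit, so the step to compound 3 cannot be read: the limit of > 3200 nM in this assay, at which 3 of the 3 values shown sit.

The compounds shown leave open whether 3-chlorophenyl in place of benzyl, or a defined configuration, changes the result in this assay at all.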